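The source may hold more compounds than are shown below. What is called first, only, known or untested is meant among the compounds shown, and "the series" means these compounds.

Within the data shown here, compound 2 `CCCCCc1ccc(-c2cn(C[C@H](O)[C@H]3OC(=O)C(OCc4ccccc4)=C3OCc3ccccc3)nn2)cc1` is the only member of this set with a numeric value in a functional assay on CFPAC-1 cells (Homo sapiens) for antiproliferative activity, read by MTT assay, with a stated time of 72 h; on this read-out higher numbers stand for weaker inhibition and lower numbers for stronger inhibition: compound 2 gives 9890 nM. Compound 3 `CC(C)(C)OC(=O)N1CCN(C(=S)SCc2cn(C[C@H](O)[C@H]3OC(=O)C(OCc4ccccc4)=C3OCc3ccccc3)nn2)CC1` sits at a limit of the assay, > 100000 nM, which is not a number. Compound 1 `O=C1O/C(=C\Cn2cc(-c3cc(F)cc(F)c3)nn2)C(OCc2ccccc2)=C1OCc1ccccc1` is recorded in this assay as "not active" (no number reported). Among the measured compounds shown here, no two measured compounds differ in one place, so no measured step is available; the only pointer to spread is the limit of > 100000 nM in this assay, at which 1 of the 3 values shown sits. Compound 4 `O=C1O[C@H]([C@@H](O)Cn2cc(CNS(=O)(=O)c3ccc(Cl)cc3)nn2)C(OCc2ccccc2)=C1OCc1ccccc1` differs from compound 2 by (((4-chlorophenyl)sulfonyl)amino)methyl in place of 4-pentylphenyl on an aromatic carbon. For the measured compounds named here, with no measured step to lean on, a step toward weaker inhibition, beyond the scatter, is expected, a 2.5-fold higher number from compound 2 to compound 4 (0.40 log units; beyond the scatter). Compound 4 is estimated at 25000 nM in this assay, with a range from 6000 nM to 100000 nM.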

Compound 4, half-maximal inhibitory concentration: 38900 nM
Compound 4: middle estimate off by 1.6-fold (0.19 log units), on the low side; the range from low to high includes it.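

In this assay, among these compounds, (((4-chlorophenyl)sulfonyl)amino)methyl in place of 4-pentylphenyl on the aromatic carbon of the five-membered aromatic ring gives a 3.9-fold higher number from compound 2 to compound 4 (0.59 log units; beyond the scatter), the first measured step in the set. This position therefore responds to the group it carries, though both groups give a numeric value. The only pointer to a wider spread remains a limit, which is not a number: the limit of > 100000 nM in this assay, at which 1 of the 4 values shown sits.

The compounds shown do not separate the contribution of the sulfonyl amino linker from that of the 4-chlorophenyl ring. A simple amine or a longer alkyl chain at this position would help to distinguish them.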